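The compounds below may be only part of what the source reports. "The series", "measured", "known", "first", "only" and "open" are said of these compounds alone.

Compound 1 `O=S(=O)(Cc1nc(-c2ccnc(Cl)c2)c2sccc2n1)c1cccc(Cl)c1`: 63000 nM
Compound 2 `COc1ccc(-c2nc(CSc3cc(C)cc(C)c3)nc3ccsc23)cn1`: reported as a limit

Of the compounds shown here, two have been measured in an ADME assay on cells (Homo sapiens) for cytotoxicity, read by resazurin assay, with a stated time of 5 days; a lower number here means that less compound is tolerated, a higher number that more compound is tolerated. Going by the values given here, compound 1 gives 63000 nM, the only numerical value in the set. For compound 2 the result is a limit rather than a number, > 50000 nM, and this is the only other entry in this assay (the limit of > 50000 nM in this assay, at which 1 of the 2 values shown sits). Among the compounds with values here, with a single number and a single limit, compound 1 cannot be placed relative to anything else on a scale; it simply stands as the one defined value.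

Compound 3 `COc1ccc(-c2nc(CS(=O)(=O)c3cccc(Cl)c3)nc3ccsc23)cc1` has not yet been measured. It differs from compound 1 in one place: 4-methoxyphenyl in place of 2-chloropyridin-4-yl on an aromatic carbon. Within the data shown here, no step between two measured compounds is known here, so there is no measured step of this kind to lean on.

The expectation is that the change makes little difference in this assay, with the step from compound 1 to compound 3 estimated at a 1.1-fold lower number from compound 1 to compound 3 (0.02 log units; within the scatter), within the usual scatter. Compound 3 is therefore expected to give about 60000 nM, with a likely range from 25000 nM to 150000 nM, and a real chance that only a limit is reported.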

Compound 3, half-maximal cytotoxic concentration: 69000 nM
Estimate against measurement, compound 3: 1.2-fold (0.06 log units) below, and the stated range covers the measured number.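

In this assay, going by these compounds alone, placing 4-methoxyphenyl instead of 2-chloropyridin-4-yl on this aromatic carbon, next to the ring nitrogen, gives a 1.1-fold higher number from compound 1 to compound 3 (0.04 log units; within the scatter); this is the first measured step at this position. Compound 1 and compound 3 therefore cannot be told apart in this read-out, even though the exchange swaps a six-membered aromatic ring with a hetero atom for one of carbon only, and removes the chlorine while adding the methoxy group. Within the data shown here, what the earlier compounds could not show is that this one exchange on the shared core, with the rest of compound 1 kept, leaves the half-maximal cytotoxic concentration within the usual scatter.

This single step does not say how the position would respond to an amine or a carboxylic acid on the ring, or to a longer chain in its place, so it cannot be read as a general tolerance for any group here. Compound 2 stands only as a limit and gives no number to set against a defined value: the limit of > 50000 nM in this assay, at which 1 of the 3 values shown sits.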